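The compounds below may be only part of what the source reports. "The series", "measured", "known", "first", "only" and "open" are said of these compounds alone.

Measured so far in a functional assay on HCT-116 cells (Homo sapiens) for inhibition, read by MTT assay, with a stated time of 72 h; a lower number here means a stronger inhibitor, a higher number a weaker inhibitor:
compound 1, `CCOC(=O)c1oc2ccc(NS(=O)(=O)c3ccc(Cl)cc3)cc2c1C`, gives > 40000 nM.
compound 2, `CCOC(=O)c1oc2ccc(NS(=O)(=O)c3ccc(F)cc3)cc2c1C`, gives > 40000 nM.

Both of these values are limits of the assay, not numbers. Compound 1 stands at the limit of > 40000 nM in this assay, at which 2 of the 2 values shown sit, and its value of > 40000 nM is such a limit. Compound 2 likewise sits at that limit with > 40000 nM. For the measured compounds named here, the only measured step, a step that the two limits leave unreadable from compound 1 to compound 2, is therefore unreadable because both ends rest on (the limit of > 40000 nM in this assay, at which 2 of the 2 values shown sit); the exchange of fluoro for chloro on an aromatic carbon tells nothing about size or direction here.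

The compound still to be measured is compound 3, `CCOC(=O)c1oc2ccc(N(C(C)C)S(=O)(=O)c3ccc(Cl)cc3)cc2c1C`. It differs from compound 1 by isopropyl in place of hydrogen on a sulfonamide nitrogen. No measured step involves a change on the sulfonamide nitrogen, so nothing among the shown data bears directly on this step, and the one step that exists could not be read. With compound 1 already at the limit, compound 3 is expected to give 50000 nM, with a range from 15000 nM to 200000 nM. The expected step is a step that the limit leaves unreadable from compound 1 to compound 3, most likely again reported only as a limit.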

Compound 3, half-maximal inhibitory concentration: > 40000 nM
Compound 3: only a limit was reported (the forecaster's own chance of this, stated with the estimate: 80%); the middle value lies beyond the limit too.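

Compound 3 gives > 40000 nM, which is a limit of the assay and not a number. No size or direction can therefore be read for the change from compound 1 to compound 3, because both ends rest on a limit: the limit of > 40000 nM in this assay, at which 3 of the 3 values shown sit.

The compounds shown leave open whether isopropyl in place of hydrogen on a sulfonamide nitrogen changes the inhibition at all.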